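Side-chain notes: oxan-3-yl to 1-ethylpiperidin-4-yl

The source may hold more compounds than are shown below. What is called first, only, known or untested is meant among the compounds shown, and "the series" means these compounds.

Of the compounds shown here, two on the shared core have numbers so far in a functional assay on RS4-11 cells (Homo sapiens) for inhibition, read by CCK-8 assay, with a stated time of 72 h; on this read-out lower numbers stand for stronger inhibition and higher numbers for weaker inhibition. There, compound 1 `CCN(CC)CCCNc1ccc(S(=O)(=O)NC(=O)c2ccc(N3CCN(CC4=C(c5ccc(C(F)(F)F)cc5)CC(C)(C)CC4)CC3)cc2Oc2cnc3[nH]ccc3c2)cc1[N+](=O)[O-]` gives 3 nM and compound 2 `CC1(C)CCC(CN2CCN(c3ccc(C(=O)NS(=O)(=O)c4ccc(OCC5CCCOC5)c([N+](=O)[O-])c4)c(Oc4cnc5[nH]ccc5c4)c3)CC2)=C(c2ccc(C(F)(F)F)cc2)C1` gives 12 nM, the higher of the two numbers.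

Compound 3 `CCN1CCC(COc2ccc(S(=O)(=O)NC(=O)c3ccc(N4CCN(CC5=C(c6ccc(C(F)(F)F)cc6)CC(C)(C)CC5)CC4)cc3Oc3cnc4[nH]ccc4c3)cc2[N+](=O)[O-])CC1` is still unmeasured. Its difference from compound 2 is 1-ethylpiperidin-4-yl in place of oxan-3-yl on a saturated chain carbon bound to an oxygen on an aromatic ring. The six-membered non-aromatic ring remains, with nitrogen as its hetero atom instead of oxygen.

Going by the values given here, only one measured step bears on this change: a 4.0-fold higher number from compound 1 to compound 2 (0.60 log units; beyond the scatter). In that modest step, a nitrogen-bearing group without a ring gave way to the oxygen-bearing ring group. Compound 3 restores nitrogen but not the group of compound 1, so only a partial return towards 3 nM is expected, and a single step is thin support. The estimated step is a 2.0-fold lower number from compound 2 to compound 3 (0.30 log units; within the scatter), towards a lower number and modest at most. For compound 3 the expected value is 6 nM, with an estimated range of 2 nM to 20 nM.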

Compound 3, half-maximal inhibitory concentration: 4.9 nM
Beside the measured number, compound 3's estimate is 1.2-fold (0.09 log units) above it; the range from low to high includes it.
By their numbers in this assay, from the lowest: compounds 1 and 3 (each within the scatter of the next); then compound 2.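

In this assay, 1-ethylpiperidin-4-yl in place of oxan-3-yl on a saturated chain carbon bound to an oxygen on an aromatic ring gives a 2.4-fold lower number from compound 2 to compound 3 (0.39 log units; beyond the scatter); this position therefore responds even when a six-membered non-aromatic ring with 1 hetero atom stays in place, although nitrogen for oxygen, the ethyl group and the point of ring attachment all change together. Replacing (3-(diethylamino)propyl)amino with (1-ethylpiperidin-4-yl)methoxy on an aromatic carbon gives a 1.6-fold higher number from compound 1 to compound 3 (0.21 log units; within the scatter), so on the shared core, in this assay, a side chain with a nitrogen-bearing ring and an oxygen link can match the open-chain amine group within the scatter. The compounds shown come with no measurement that explains either step.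

Still open, going by these compounds, is which part of the change carries the step: 1-methylpiperidin-4-yl, piperidin-4-yl with a free ring amine hydrogen, or cyclohexyl on the same saturated chain carbon would separate the nitrogen from the ethyl group and the ring itself. The link also remains unresolved, and (1-ethylpiperidin-4-yl)methylamino on the aromatic carbon would test the amino link with the ring kept.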